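Fluoro to trifluoromethyl in a cytotoxicity test

The compounds below may be only part of what the source reports. "The series", "measured", "known", "first", "only" and "open" are said of these compounds alone.

Compound 1 `CC(=O)Nc1ccc2oc(-c3ccc(C(F)(F)F)cc3)cc(=O)c2c1` gives 330000 nM in the test below
Compound 2 `CC(=O)Nc1ccc2oc(-c3ccc(F)cc3)c(O)c(=O)c2c1` gives 34100 nM in the test below

Both numbers come from an ADME assay on MT4 cells (Homo sapiens) for cytotoxicity, read by MTT assay, with a stated time of 4 days (on this read-out lower numbers stand for higher toxicity in this test and higher numbers for lower toxicity in this test), as the measure used here. Of the two, compound 2 has the lower number, and its gap to compound 1 lies beyond the usual scatter. Compound 3 `CC(=O)Nc1ccc2oc(-c3ccc(C(F)(F)F)cc3)c(O)c(=O)c2c1` has not yet been measured. It differs from compound 2 by trifluoromethyl in place of fluoro on an aromatic carbon, para to a large group trifluoromethyl in place of fluoro on an aromatic carbon and in nothing else. Among the measured compounds shown here, no measured pair shows this swap alone. Compound 1, which also bears trifluoromethyl, gives 330000 nM but differs from compound 2 elsewhere too, so that number cannot simply be carried over. A small upward step is expected, possibly none beyond the scatter. The estimated move is a 1.3-fold higher number from compound 2 to compound 3 (0.12 log units; within the scatter) in this test. Compound 3 is expected at 45000 nM with an estimated range from 14000 nM to 150000 nM in this test.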

Compound 3, half-maximal cytotoxic concentration: 7300 nM
The estimate for compound 3 lay 6.2-fold (0.79 log units) above the measured number; measured number outside the range, below it.
By their numbers in this assay, from the lowest: compound 3; then compound 2; then compound 1.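

In this assay, trifluoromethyl in place of fluoro on an aromatic carbon, para to a large group, can now be read alone: it gives a 4.7-fold lower number from compound 2 to compound 3 (0.67 log units; beyond the scatter) and so this position does respond to the change, with toxicity in this test rising. Trifluoromethyl does not set that level by itself, since adding hydroxy in place of hydrogen on an aromatic carbon gives a 45-fold lower number from compound 1 to compound 3 (1.66 log units; beyond the scatter) with trifluoromethyl present in both compounds. Nothing measured here explains either step.

The compounds shown leave open whether the number follows the size of the group at this position, which a methyl or a chlorine atom there could test. They also leave open whether the hydroxy step would be as large with fluoro in place of trifluoromethyl.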